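From Methylsulfanyl to Methoxy at the Assay Limit

A few compounds are considered here, and "the series" means these few. Any claim that something is new, unique, unknown or untested is made for them only; others in the source may bear on it.

In a functional assay on K562 cells (Homo sapiens) for antiproliferative activity, read by MTT assay (a lower number here means a stronger inhibitor, a higher number a weaker inhibitor), compound 1 (`O=C(CCl)NC(=O)N1CCCc2cc(S(=O)(=O)N3CC(c4ccccc4)NC3=O)ccc21`) gives 515 nM, a measured number. Compound 2 (`CC1(c2ccccc2)CN(S(=O)(=O)c2ccc3c(c2)CCCN3C(=O)C(F)(F)F)C(=O)N1`) gives > 20000 nM, which is a limit of the assay. Compound 3 (`CSc1ccc(NC(=O)N2CCCc3cc(S(=O)(=O)N4CC(C)(c5ccccc5)NC4=O)ccc32)cc1`) gives > 20000 nM, again a limit and not a number. The evidence on this point is brief: the limit of > 20000 nM in this assay, at which 2 of the 3 values shown sit. Among the compounds with values here, the one measured step, a step that the two limits leave unreadable from compound 2 to compound 3, has no readable size, so it offers no magnitude to carry forward.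

Compound 4 (`COc1ccc(NC(=O)N2CCCc3cc(S(=O)(=O)N4CC(C)(c5ccccc5)NC4=O)ccc32)cc1`) carries methoxy in place of methylsulfanyl on an aromatic carbon, para to a large group: methoxy in place of methylsulfanyl on an aromatic carbon. Within the data shown here, no measured step covers this exchange. With compound 3 at > 20000 nM, compound 4 is expected to remain near that limit in this assay, and no direction of change can be read. The expected change is a number no higher from compound 3 to compound 4 (the limit leaves the size open), with nothing beyond the scatter anticipated. For compound 4 the estimate is 20000 nM, with an expected range from 6000 nM to 60000 nM.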

Compound 4, half-maximal inhibitory concentration: 12400 nM
For compound 4 the middle estimate is 1.6-fold (0.21 log units) above the measured one, and the stated range covers the measured number.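

Methoxy in place of methylsulfanyl on this aromatic carbon, para to a large group, gives the first step in this assay with a readable floor: an at least 1.6-fold lower number from compound 3 to compound 4 (0.20 log units; that floor lies within the scatter). Set against the trifluoromethyl on a carbonyl carbon, the (4-methoxyphenyl)amino group gives an at least 1.6-fold lower number from compound 2 to compound 4 (0.20 log units; that floor lies within the scatter). Neither step has a known full size, and each shows only a floor within the scatter, because one end of each step is an assay limit: the limit of > 20000 nM in this assay, at which 2 of the 4 values shown sit.

As far as these compounds go, whether an amine, a carboxylic acid or a longer chain such as ethoxy on this aromatic carbon would give a lower number than compound 4 remains open. From the compounds shown here alone, the true value of compound 3 also stays open, since it holds only a limit.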